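The compounds below may be only part of what the source reports. "The series", "measured", "known", "first", "only" and "open" are said of these compounds alone.

Measured so far in an ADME assay on MRC5 cells (Homo sapiens) for cytotoxicity, read by resazurin assay, with a stated time of 72 h; on this read-out higher numbers stand for weaker inhibition and lower numbers for stronger inhibition

- Compound 1 `O=[N+]([O-])c1cn2c(n1)OC(COc1cccc(-c3ccc(F)cc3F)n1)CC2` gives > 64000 nM (a limit)
- Compound 2 `O=[N+]([O-])c1cn2c(n1)OC(COc1cccc(-c3ccc(F)cc3)n1)CC2` gives 59000 nM

Compound 1 reads > 64000 nM and that is a limit of the assay, not a number. Within the data shown here, compound 2 stands at 59000 nM as the only true number in this assay so far. Among the measured compounds shown here, the single measured step is an at least 1.0-fold lower number from compound 1 to compound 2 (0.03 log units; that floor lies within the scatter) and it puts hydrogen in place of fluoro on an aromatic carbon.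

Compound 3 `O=[N+]([O-])c1cn2c(n1)OC(COc1cccc(-c3ccc(F)nc3)n1)CC2` keeps the shared core of compound 2 and carries 6-fluoropyridin-3-yl in place of 4-fluorophenyl on an aromatic carbon gives the full count. For the measured compounds named here, no measured step swaps a ring carbon for nitrogen, so the one step available is only a loose guide. With compound 2 at 59000 nM as the starting point and that step lying within the scatter, no step beyond the scatter is expected in this assay for this change. The estimated change is a 1.0-fold higher number from compound 2 to compound 3 (0.01 log units; within the scatter) and no clear direction is expected. Compound 3 may also return only a limit. Compound 3 is expected at 60000 nM with an estimated range from 30000 nM to 120000 nM around that figure.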

Compound 3, half-maximal inhibitory concentration: 35000 nM
Beside the measured number, compound 3's estimate is 1.7-fold (0.23 log units) above it; low and high end bracket the measured number.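

In this assay, among these compounds, the earlier compounds changed only a fluoro on a carbon-only ring, whereas 6-fluoropyridin-3-yl in place of 4-fluorophenyl now changes the ring itself and gives a 1.7-fold lower number from compound 2 to compound 3 (0.23 log units; within the scatter). This position therefore accepts a ring with a nitrogen in it without a step beyond the scatter, at least for this pair. Compound 1 gives > 64000 nM, which is a limit of the assay and not a number, so 6-fluoropyridin-3-yl in place of 2,4-difluorophenyl can be read only as a floor, an at least 1.8-fold lower number from compound 1 to compound 3 (0.26 log units; that floor lies within the scatter), and the true step may be larger, because one end of it rests on a limit: the limit of > 64000 nM in this assay, at which 1 of the 3 values shown sits.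

Going by these compounds, all three compounds carry fluoro on this ring, so the effect of the ring nitrogen without any fluoro, as in a plain pyridin-3-yl group, remains open. Also open is how this assay would respond to an amine or a carboxylic acid at this place, since the three rings shown carry only fluoro.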